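A few compounds are considered here, and "the series" means these few. Any claim that something is new, unique, unknown or untested is made for them only; others in the source may bear on it.

Compound 1 `O=C(/C=C/c1cccnc1)NCCCCCCCc1ccc(S(=O)(=O)Nc2ccccc2)cc1`: 223 nM
Compound 2 `Cc1cccc(NS(=O)(=O)c2cccc(CCCCCCNC(=O)/C=C/c3cccnc3)c2)c1`: 65.8 nM

Both values come from a functional assay on HeLa cells (Homo sapiens) for inhibition, read by CCK-8 assay, with a stated time of 72 h; a higher number here means a weaker inhibitor, a lower number a stronger inhibitor. Of the two, compound 2 has the lower number, at 65.8 nM, while compound 1 stands at 223 nM. That gap lies beyond the usual scatter of repeated measurements, so compound 2 is the stronger inhibitor of this pair.

The next compound, compound 3 `O=C(/C=C/c1cccnc1)NCCCCCCc1cccc(S(=O)(=O)Nc2ccc(F)cc2)c1`, has not yet been measured. It differs from compound 2 in one place, with 4-fluorophenyl in place of 3-methylphenyl on a sulfonamide nitrogen.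

Among the compounds with values here, no measured pair shows what a change at this nitrogen does in this assay, so the expectation has no direct precedent. Within the data shown here, with only two numbers available, and compound 2 the lower at 65.8 nM, a small rise seems more likely than a further drop, and the step may well stay within the scatter. The estimate amounts to an expected 1.3-fold higher number from compound 2 to compound 3 (0.11 log units; within the scatter). Compound 3 is expected at 85 nM, with an estimated range from 28 nM to 260 nM.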

Compound 3, half-maximal inhibitory concentration: 99.9 nM
The estimate for compound 3 lay 1.2-fold (0.07 log units) below the measured number; the range from low to high includes it.
By their numbers in this assay, from the lowest: compounds 2 and 3 (each within the scatter of the next); then compound 1.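

In this assay, the exchange of 3-methylphenyl for 4-fluorophenyl on the sulfonamide nitrogen gives a 1.5-fold higher number from compound 2 to compound 3 (0.18 log units; within the scatter), so this pair cannot be told apart and the assay registers no meaningful difference between these two aryl groups. Within the data shown here, this is the first reading at this position, and it shows that an aryl group of the same heavy-atom count can carry a fluorine rather than a methyl group, at a different place on the ring, while the number stays within the scatter of that for compound 2. No measurement available here accounts for this result or says what the two groups contribute.

Going by these compounds, one step cannot separate the identity of the ring substituent from its place, so it remains open whether 3-fluorophenyl or 4-methylphenyl would read the same way as compound 2 and compound 3. On these data alone, it also remains open how far this tolerance extends on the sulfonamide nitrogen, for instance to a pyridyl ring, a phenyl ring carrying a carboxylic acid or an amine, or a simple methyl group in place of the aryl ring.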